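The source may report more compounds than this note shows. Statements on the series, on what has been measured and on what is new or still open speak of the compounds shown alone.

In a functional assay on SK-OV-3 cells (Homo sapiens) for antiproliferative activity, read by MTT assay, with a stated time of 48 h (a higher number here means a weaker inhibitor, a lower number a stronger inhibitor), the measured compounds so far are:

compound 1 `CCNC(=O)Nc1nc(-c2ccc(OCC)cc2)c(-c2cc(OC)c(OC)c(OC)c2)s1` gives 29.2 nM
compound 2 `CCOc1ccc(-c2sc(N)nc2-c2cc(OC)c(OC)c(OC)c2)cc1` gives 8.4 nM
compound 3 `CCOc1ccc(-c2nc(NS(=O)(=O)c3ccccc3C(F)(F)F)sc2-c2cc(OC)c(OC)c(OC)c2)cc1` gives > 5000 nM as a limit of the assay and not a number

Of the two actual numbers, compound 1 at 29.2 nM stands higher, which makes it the weaker inhibitor of that pair, and compound 2 at 8.4 nM lies beyond the usual scatter from it.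

Compound 4 `CCCN(CCC)c1nc(-c2ccc(OCC)cc2)c(-c2cc(OC)c(OC)c(OC)c2)s1` has not yet been tested. It has dipropylamino in place of (ethylcarbamoyl)amino on an aromatic carbon and otherwise matches compound 1. Among the measured compounds shown here, no measured pair differs in one place alone, so no direct guide exists for this change. A move to a higher number in this assay is expected, beyond the scatter, meaning a weaker inhibitor. This expectation leans on compound 1 at 29.2 nM standing above compound 2 at 8.4 nM and that is a thin basis. The expected size of the move is an 8.6-fold higher number from compound 1 to compound 4 (0.93 log units; beyond the scatter) and it remains uncertain. For compound 4 the estimate is 250 nM with 40 nM to 2000 nM as its expected range.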

Compound 4, half-maximal inhibitory concentration: > 5000 nM
Compound 4: only a limit was reported (the forecaster's own chance of this, stated with the estimate: 10%); at least 20-fold (1.30 log units) between middle value and limit.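

In this assay, placing dipropylamino instead of (ethylcarbamoyl)amino on this aromatic carbon gives an at least 170-fold higher number from compound 1 to compound 4 (2.23 log units; beyond the scatter), a large step and the only one shown that isolates a change at this position. Compound 4 gives > 5000 nM, which is a limit of the assay and not a number. The position is therefore not indifferent to the group it carries, but the true size of the step stays unknown, as the read-out ends at this limit: the limit of > 5000 nM in this assay, at which 2 of the 4 values shown sit.

The change removes the carbonyl and the hydrogen-bond donors and adds propyl chains all at once, so the compounds shown cannot say which of these matters. Also open, on these data alone, is how groups such as methylamino, dimethylamino or acetylamino would behave at this place.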